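The source may report more compounds than this note shows. Statements on the series, on what has been measured and on what is new or still open speak of the compounds shown alone.

Measured in a functional assay on KB cells (Homo sapiens) for antiproliferative activity, read by sulforhodamine B assay, with a stated time of 48 h; on this read-out higher numbers stand for weaker inhibition of growth and lower numbers for stronger inhibition of growth:
- compound 1 `COc1ccc(S(=O)(=O)Nc2cccc(CCc3ccc(C(=O)Nc4ccccc4N)cc3)c2)cc1`: 678 nM
- compound 2 `COc1ccc(S(=O)(=O)Nc2ccccc2CCc2ccc(C(=O)NO)cc2)cc1`: > 10000 nM
- compound 3 `COc1cccc(S(=O)(=O)Nc2ccccc2CCc2ccc(C(=O)Nc3ccccc3N)cc2)c1`: 462 nM

Compound 2 stands at > 10000 nM, which is a limit of this assay and not a number. For the measured compounds named here, it is the only compound of the three at the limit of > 10000 nM in this assay, at which 1 of the 3 values shown sits, so its true position is unknown.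

Compound 4 `COc1ccc(S(=O)(=O)Nc2ccccc2CCc2ccc(C(=O)Nc3ccccc3O)cc2)cc1` keeps the core of compound 2 and carries 2-hydroxyphenyl in place of hydroxy on an amide-type nitrogen.

Going by the values given here, no measured step isolates this change. The nearest guide is that compound 1 gives 678 nM and compound 3 gives 462 nM, and both of these also bear a substituted phenyl ring on that nitrogen. Their substituent is not hydroxy, however, so they support only a cautious expectation. A modest move towards stronger inhibition of growth is expected, estimated as an at least 2.0-fold lower number from compound 2 to compound 4 (0.30 log units; that floor lies within the scatter), and compound 4 may well remain at the limit. For compound 4 the estimated value is 5000 nM, with an expected range of 1200 nM to 20000 nM.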

Compound 4, concentration for 50% growth inhibition: 472 nM
The estimate for compound 4 lay 11-fold (1.03 log units) above the measured number, and the stated range ends above it.
By their numbers in this assay, from the lowest: compounds 3, 4 and 1 (each within the scatter of the next). At a limit, above all of these: compound 2.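

In this assay, the amide-type nitrogen of this core accepts a much larger substituent than hydroxy and still gives a measured number: 2-hydroxyphenyl in place of hydroxy brings an at least 21-fold lower number from compound 2 to compound 4 (1.32 log units; beyond the scatter). For the compounds shown here, this is the first step read at this position, and it shows that this single change is enough to bring compound 4 off the limit. The true size of the step remains a bound, since the value of compound 2 is a limit and not a number: the limit of > 10000 nM in this assay, at which 1 of the 4 values shown sits.

On these data alone, it remains open how much of the step belongs to the phenyl ring and how much to its hydroxy, a question that a plain phenyl on the same nitrogen would address. As far as these compounds go, the effect of a carboxylic acid in place of the hydroxycarbamoyl group on this core is also open.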